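The compounds below may be only part of what the source reports. "The series", "measured", "known", "first", "only" and "open" are said of these compounds alone.

Measured so far:
compound 1, `O=C(Nc1ccc2nc(NC(=O)C3CCCCC3)sc2c1)c1cccc(Oc2ccccc2)c1`: > 4 ug/mL
compound 2, `CCCC(=O)Nc1nc2ccc(NC(=O)c3c(Cl)cccc3Cl)cc2s1`: 0.01 ug/mL

Going by the values given here, in a functional assay on WI-38 VA13 cells (Homo sapiens) for cytotoxicity (on this read-out lower numbers stand for an effect already at smaller amounts and higher numbers for an effect only at larger amounts of compound), compound 2 gives 0.01 ug/mL, the only plain number among the two values shown. The other value belongs to compound 1 and sits at the limit of > 4 ug/mL in this assay, at which 1 of the 2 values shown sits, a limit of the assay rather than a number.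

Compound 3, `CCCCCNc1nc2ccc(NC(=O)c3c(Cl)cccc3Cl)cc2s1`, has not been measured. It differs from compound 2 by pentyl in place of propylcarbonyl on a nitrogen on an aromatic ring. Among the compounds with values here, no measured pair shows this change, so its size is open. A step from compound 2 to compound 3 of a 10-fold higher number from compound 2 to compound 3 (1.00 log units; beyond the scatter) is expected, towards an effect only at larger amounts. Compound 3 is therefore estimated at 0.1 ug/mL, between 0.01 ug/mL and 2 ug/mL.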

Compound 3, half-maximal effective concentration: 0.27 ug/mL
The estimate for compound 3 lay 2.7-fold (0.43 log units) below the measured number; the range from low to high includes it.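

In this assay, changing only the group on this nitrogen gives a 27-fold higher number from compound 2 to compound 3 (1.43 log units; beyond the scatter), so this position responds strongly to what sits on it. Propylcarbonyl and pentyl are both open chains of equal heavy-atom count, yet the swap, which removes the carbonyl oxygen, still moves the number clearly. Nothing shown gives a cause for this step. Still open, as far as these compounds go, is whether a butyl group, a shorter chain than pentyl, would behave like pentyl, which would show whether chain length or the missing carbonyl matters. From the compounds shown here alone, how an amine or a carboxylic acid at the chain end would fare also remains unknown.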